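This account rests on a few compounds, and the source may have more. Where it says the series, first, only, none or still open, it means among the compounds named here.

Measured so far:
compound 1 `CN(Cc1ccco1)C1CCN(CCCc2c[nH]c3ccc(-n4cnnc4)cc23)CC1` — in an assay on CHO cells for displacement of a labelled ligand from 5-hydroxytryptamine receptor 1D (Homo sapiens) (a higher number here means a weaker inhibitor, a lower number a stronger inhibitor), compound 1 gives 9.3 nM
compound 2 `C[C@@H](NCC1CCN(CCCc2c[nH]c3ccc(-n4cnnc4)cc23)CC1)c1ccccc1` — in this assay compound 2 gives 1.4 nM

Among the measured compounds shown here, compound 2 stands lowest of the two numbers; the single step of a 6.6-fold lower number from compound 1 to compound 2 (0.82 log units; beyond the scatter) separates it from compound 1. Compound 3 `C[C@H](NCC1CCN(CCCc2c[nH]c3ccc(-n4cnnc4)cc23)CC1)c1ccccc1` is its mirror form: the two compounds have the same atoms and bonds and differ only in configuration as drawn: 1 of 1 stereo elements differ; a stereocentre at a saturated chain carbon is drawn R in compound 2 and S in compound 3. For the measured compounds named here, no measured step bears on configuration alone; the one step recorded alters the whole amine and so gives no direct guide. With nothing in the data to favour the drawn S form, a modest rise is expected, a 3.6-fold higher number from compound 2 to compound 3 (0.55 log units; beyond the scatter), and for compound 3 in this assay the estimate is 5 nM (range 1.2 nM to 30 nM).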

Compound 3, half-maximal inhibitory concentration: 4.4 nM
Compound 3: the middle estimate sits 1.1-fold (0.06 log units) above what was measured; low and high end bracket the measured number.
By their numbers in this assay, from the lowest: compound 2; then compound 3; then compound 1.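

In this assay the stereocentre at the saturated chain carbon counts by itself, with a 3.1-fold higher number from compound 2 to compound 3 (0.50 log units; beyond the scatter); the step reads as one of configuration alone because of this: the fact that compounds 2 and 3 differ only in the configuration as drawn.
The ((1-phenylethyl)amino)methyl group in place of ((furan-2-yl)methyl)(methyl)amino still lowers the number with the S form, with a 2.1-fold lower number from compound 1 to compound 3 (0.33 log units; beyond the scatter), so the gain over compound 1 does not depend on the R form alone.

Open, on these data alone, is whether the two mirror forms keep this order when the phenyl is replaced by a pyridyl ring, or when the amine nitrogen carries a methyl group.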